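A few compounds are considered here, and "the series" means these few. Any claim that something is new, unique, unknown or untested is made for them only; others in the source may bear on it.

Compound 1 `COc1ccccc1CN1CCN(c2ccc(C(=O)NS(=O)(=O)c3ccc(N[C@H](CCN(C)C)CSc4ccccc4)c([N+](=O)[O-])c3)cc2)CC1` gives 950 nM in a functional assay (FL5.12 cells, Mus musculus) with Apoptosis regulator Bcl-2 (Homo sapiens) as the target; on this read-out lower numbers stand for an effect already at smaller amounts and higher numbers for an effect only at larger amounts of compound. Among the measured compounds shown here, compound 2 `CN(C)CC[C@H](CSc1ccccc1)Nc1ccc(S(=O)(=O)NC(=O)c2ccc(N3CCN(Cc4ccccc4S(C)(=O)=O)CC3)cc2)cc1[N+](=O)[O-]` gives 6800 nM in this assay, the highest of the two numbers known; the only measured step, a 7.2-fold higher number from compound 1 to compound 2 (0.85 log units; beyond the scatter), links it to compound 1. Compound 3 `CN(C)CC[C@H](CSc1ccccc1)Nc1ccc(S(=O)(=O)NC(=O)c2ccc(N3CCN(Cc4ccccc4-c4cccnc4)CC3)cc2)cc1[N+](=O)[O-]` differs from compound 2 by pyridin-3-yl in place of methylsulfonyl on an aromatic carbon. For the measured compounds named here, no measured step bears directly on this exchange: the one known step, a 7.2-fold higher number from compound 1 to compound 2 (0.85 log units; beyond the scatter), concerns the same aromatic carbon but swaps methoxy for methylsulfonyl, and it shows only that the group on that carbon can shift the number in this assay by a modest step. From the compounds shown here alone, with an aromatic ring entering in place of methylsulfonyl, the direction stays open, a return toward the number of compound 1 being as plausible as a further rise. The step expected from compound 2 to compound 3 is therefore a 2.7-fold lower number from compound 2 to compound 3 (0.43 log units; beyond the scatter). The estimate for compound 3 is 2500 nM, with an expected range from 500 nM to 12000 nM.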

Compound 3, half-maximal effective concentration: 820 nM
Compound 3: middle estimate off by 3.0-fold (0.48 log units), on the high side; low and high end bracket the measured number.
By their numbers in this assay, from the lowest: compounds 3 and 1 (each within the scatter of the next); then compound 2.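

In this assay, pyridin-3-yl in place of methylsulfonyl on this aromatic carbon gives an 8.3-fold lower number from compound 2 to compound 3 (0.92 log units; beyond the scatter) and so undoes the whole of the earlier step away from compound 1. Pyridin-3-yl in place of methoxy gives a 1.2-fold lower number from compound 1 to compound 3 (0.06 log units; within the scatter), which lies within the scatter, so these two quite different groups cannot be told apart on this read-out. Of the three groups shown at this place, ortho to a large group, only methylsulfonyl stands apart, with compound 2 beyond the scatter from both compound 1 and compound 3.

The compounds shown leave open whether the ring nitrogen of pyridin-3-yl counts for anything here, for which a plain phenyl group would be the comparison, and how an amine or a carboxylic acid on this carbon would read. Nothing at hand explains why methylsulfonyl stands apart.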